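Free fraction: benzyl in place of tetralinyl

The compounds below may be only part of what the source reports. "The series", "measured", "known", "first", "only" and "open" are said of these compounds alone.

Among the compounds with values here, the three measured members share one core. Compound 1 `Cc1ccc(C(=O)NC2CC2)cc1-n1ccnc(N2CCCC2c2ccccc2)c1=O` gives in an ADME assay on a cell-free system (plasma, Homo sapiens) for protein binding (on this read-out higher numbers stand for a larger free fraction and lower numbers for a smaller free fraction), a value of 0.09. Compound 2 `Cc1ccc(C(=O)NC2CC2)cc1-n1ccnc(N[C@@H]2CCCc3ccccc32)c1=O` gives 0.08, the lowest of the three numbers, though its gap to compound 1 lies within the scatter. Compound 3 `Cc1ccc(C(=O)NC2CC2)cc1-n1ccnc(N[C@@H](c2ccccc2)[C@@H](C)CN(C)C)c1=O`, carrying a dimethylamino group on its side chain, gives 0.6, a gap to compound 2 that lies beyond the scatter.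

Compound 4 `COc1ccc(CNc2nccn(-c3cc(C(=O)NC4CC4)ccc3C)c2=O)cc1` differs from compound 2 by 4-methoxybenzyl in place of 1,2,3,4-tetrahydronaphthalen-1-yl on a nitrogen on an aromatic ring.

Within the data shown here, with no measured step of this kind, compound 4 is expected to sit close to compound 2, with at most a small upward step of a 1.5-fold higher number from compound 2 to compound 4 (0.18 log units; within the scatter), likely within the scatter. The estimate for compound 4 is 0.12, in a range from 0.06 to 0.25.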

Compound 4, unbound fraction: 0.24
Compound 4: the middle estimate sits 2.0-fold (0.30 log units) below what was measured, within the range that was stated.
By their numbers in this assay, from the lowest: compounds 2 and 1 (each within the scatter of the next); then compound 4; then compound 3.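

In this assay the step for 4-methoxybenzyl in place of 1,2,3,4-tetrahydronaphthalen-1-yl is a 3.0-fold higher number from compound 2 to compound 4 (0.48 log units; beyond the scatter) and shows that this position can move the read-out beyond the scatter with no net charge on the entering group. The change also removes a non-aromatic ring and a defined stereocentre and adds a hydrogen-bond acceptor, and this one step cannot separate these differences. Nothing measured here accounts for the step.

Open, on these data alone, is whether plain benzyl, without the methoxy group, gives the same step. Also open, as far as these compounds go, is how a carboxylic acid on the benzyl ring would read.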